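A few compounds are considered here, and "the series" means these few. Any claim that something is new, unique, unknown or untested is made for them only; others in the source may bear on it.

Measured so far: compound 1 `CCCc1ccc(NC(=O)N[C@H](C)c2ccccc2)cc1`, compound 2 `CCCc1ccc(NC(=O)N[C@@H](C)c2ccccc2)cc1`, compound 3 `CCOC(=O)c1cccc(NC(=O)N[C@H](C)c2ccccc2)c1`.

In an ADME assay on the whole organism with Oryza sativa as the target, tested at 1 uM (on this read-out lower numbers stand for a stronger effect and higher numbers for a weaker effect at the one concentration tested), compound 1 gives 31%, compound 2 gives 76% and compound 3 gives 94%. Compound 2 thus stands second highest of the three. Among the compounds with values here, the only step between measured compounds, a number 45 percentage points higher from compound 1 to compound 2 (beyond the scatter), rests on the fact that compounds 1 and 2 differ only in the configuration as drawn alone. Compound 4 `CCOC(=O)c1ccc(NC(=O)N[C@@H](C)c2ccccc2)cc1` is compound 2 with ethoxycarbonyl in place of propyl on an aromatic carbon. Within the data shown here, no measured step covers this exchange, so its size cannot be read from a pair already seen; only compound 3, which also carries ethoxycarbonyl and gives 94%, offers a hint. A modest rise in this assay is therefore expected, a number 9 percentage points higher from compound 2 to compound 4 (within the scatter), possibly no larger than the scatter. Compound 4 is estimated at 85%, between 65% and 100%.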

Compound 4, a percentage reported as activity, at one concentration (the size of the read-out at that concentration, not a potency): 97%
For compound 4 the middle estimate is 12 percentage points below the measured one; the measured number falls inside the stated range.
By their numbers in this assay, from the lowest: compound 1; then compound 2; then compounds 3 and 4 (each within the scatter of the next).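

Replacing propyl with ethoxycarbonyl on this aromatic carbon gives, in this assay, a number 21 percentage points higher from compound 2 to compound 4 (beyond the scatter), a weaker effect at the one concentration tested. The earlier step changed only the drawn configuration, whereas this one shows that the group at this position also moves the number. Nothing available explains why this exchange has this effect.

As far as these compounds go, whether an amine, a carboxylic acid or a longer chain here would give a lower number remains open. A single exchange also cannot separate the effect of the added atoms from that of the carbonyl.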